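Spleen Dose Series: Side Chain at the Amine Carbon

This account rests on a few compounds, and the source may have more. Where it says the series, first, only, none or still open, it means among the compounds named here.

Compound 1 `CCCCCCCCc1ccc(CCC(N)CO)cc1` carries the simplest side chain of the set. In a functional assay on the whole organism (spleen, spleen) with Rattus norvegicus as the target (on this read-out lower numbers stand for an effect already at smaller amounts and higher numbers for an effect only at larger amounts of compound), compound 1 reaches only > 10 mg/kg, which is a limit of the assay and not a number. Compound 2 `CCCCCCCOc1ccc(CCC(N)(CC)CO)cc1` in this assay gives 0.044 mg/kg. Compound 3 `C=CCC(N)(CO)CCc1ccc(OCCCCCCC)cc1` gives 3.1 mg/kg. Compound 3 thus stands with the highest of the two numbers shown, the nearest being compound 2, separated by a 70-fold higher number from compound 2 to compound 3 (1.85 log units; beyond the scatter); the remaining value is only a limit (the limit of > 10 mg/kg in this assay, at which 1 of the 3 values shown sits).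

Compound 4 `CCCCCCCOc1ccc(CC[C@](N)(CO)CCO)cc1` is not yet measured. It differs from compound 3 at a saturated chain carbon two bonds along the chain from an aromatic carbon: a group of 7 heavy atoms (4 carbon, 1 nitrogen, 2 oxygen; no ring) in place of a group of 7 heavy atoms (5 carbon, 1 nitrogen, 1 oxygen; no ring), on a saturated chain carbon, two bonds along the chain from an aromatic carbon. Within the data shown here, the only measured step of related kind is a 70-fold higher number from compound 2 to compound 3 (1.85 log units; beyond the scatter), which concerns the same carbon and shows how strongly this assay responds to a change there; no measured step covers a hydroxyl entering, and the defined stereocentre has no precedent in the set. Because a 70-fold higher number from compound 2 to compound 3 (1.85 log units; beyond the scatter) followed the entry of the double bond at this carbon, and that double bond leaves again, for compound 4 the expected step is a 6.2-fold lower number from compound 3 to compound 4 (0.79 log units; beyond the scatter). The estimate for compound 4 is 0.5 mg/kg, with a range from 0.05 mg/kg to 5 mg/kg.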

Compound 4, dose for 50% inhibition: 4.2 mg/kg
Estimate against measurement, compound 4: 8.4-fold (0.92 log units) below; low and high end bracket the measured number.
By their numbers in this assay, from the lowest: compound 2; then compounds 3 and 4 (each within the scatter of the next). At a limit, above all of these: compound 1.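

Notes on the saturated chain carbon, two bonds along the chain from an aromatic carbon: in this assay, removing the double bond does not restore the low number of compound 2, as the new group gives a 95-fold higher number from compound 2 to compound 4 (1.98 log units; beyond the scatter). Two differently built groups at this carbon, one with a double bond outside aromatic rings and the other with an added hydroxyl and a defined stereocentre, cannot be told apart in this read-out: a 1.4-fold higher number from compound 3 to compound 4 (0.13 log units; within the scatter). The large steps away from compound 2 are therefore not tied to the double bond alone, and the data at hand contain no measurement that explains them.

On these data alone, it remains open whether a methyl or a propyl group at this carbon would give a number close to that of compound 2 or close to those of compound 3 and compound 4, which would show how narrow the tolerated range of groups is here. As far as these compounds go, it is also open whether the opposite arrangement at the stereocentre of compound 4 would change its number, so the contributions of the hydroxyl and of the stereocentre cannot yet be separated.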